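Leucine benzyl ester analogue after the two dibenzyl esters

The source may report more compounds than this note shows. Statements on the series, on what has been measured and on what is new or still open speak of the compounds shown alone.

The series shares one core carrying a cyclopropyl-bearing glycinamide linked to an amino acid benzyl ester. Compound 1 `O=C(CN(c1ncnc2c1ncn2C1CCCCO1)C1CC1)N[C@@H](CCC(=O)OCc1ccccc1)C(=O)OCc1ccccc1` gives 14.1% in a functional assay on the whole organism (Tail, strain ICR) with Mus musculus as the target, in the tail flick test, with a stated time of 150 min, at a dose of 25 umol/kg by the oral route; on this read-out higher numbers stand for a stronger effect at the one dose given and lower numbers for a weaker effect. Compound 2 `O=C(CN(c1ncnc2c1ncn2C1CCCCO1)C1CC1)N[C@@H](CC(=O)OCc1ccccc1)C(=O)OCc1ccccc1`, the shorter homologue, gives 0.06% in this assay. Among the measured compounds shown here, this is the lowest of the two numbers so far, and the single measured step runs a number 14 percentage points lower from compound 1 to compound 2 (beyond the scatter), a modest drop tied to shortening the ester-bearing chain.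

Compound 3 `CC(C)C[C@H](NC(=O)CN(c1ncnc2c1ncn2C1CCCCO1)C1CC1)C(=O)OCc1ccccc1` is to be measured in this assay. Relative to compound 2 the change is isopropyl in place of benzyloxycarbonyl on a saturated chain carbon, two bonds along the chain from an amide-type nitrogen and a carbonyl carbon. For the measured compounds named here, the only measured step concerns the length of the chain carrying benzyloxycarbonyl, not its removal, so it bears only loosely on this change; it shows that the read-out in this assay is sensitive to what sits at this chain carbon, with a swing of modest size.

Given the near-zero value of compound 2 0.06% and the moderate value of compound 1 14.1%, compound 3 is expected to give 10%, with a range from 0% to 30%. The expected step is a number 9.9 percentage points higher from compound 2 to compound 3 (within the scatter), a gain of uncertain size.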

Compound 3, a percentage reported as activity, at one dose (the size of the read-out at that dose, not a potency): 6.47%
For compound 3 the middle estimate is 3.5 percentage points above the measured one; the range from low to high includes it.
By their numbers in this assay, from the lowest: compounds 2, 3 and 1 (each within the scatter of the next, the first and the last beyond it).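

In this assay the change to isopropyl gives a number 6.4 percentage points higher from compound 2 to compound 3 (within the scatter) and, read one bond further out, isobutyl in place of (benzyloxycarbonyl)methyl gives a number 7.6 percentage points lower from compound 1 to compound 3 (within the scatter) on the same saturated chain carbon. The earlier step showed only that the two ester-bearing chains can be separated beyond the scatter; the new result adds that a group with no ring and no hydrogen-bond acceptors cannot be separated from either of them, so a benzyloxycarbonyl at the end of this chain is not needed for a read-out of this size. The data offer nothing that accounts for these values.

Open, on these data alone, is whether any group at this chain carbon lifts the read-out clearly beyond that of compound 1, for example a free carboxylic acid in place of benzyloxycarbonyl, a longer chain ending in an amine, or a phenyl ring carried directly on the chain. As far as these compounds go, all three values also rest on one dose and one stated time, so how these small differences would look at other doses remains unknown.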